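The source may report more compounds than this note shows. Statements on the series, on what has been measured and on what is new or still open speak of the compounds shown alone.

Measured so far in a functional assay on SMMC-7721 cells (Homo sapiens) for inhibition, read by CCK-8 assay, with a stated time of 72 h, tested at 8 uM; a higher number here means more inhibition of growth at the concentration tested, a lower number less inhibition of growth:
compound 1 `Nc1ccccc1NC(=O)/C=C/c1ccc(CSc2ccc(Cl)cc2)cc1`: 16.5%
compound 2 `Nc1ccccc1NC(=O)/C=C/c1ccc(CSc2ccc(C(F)(F)F)cn2)cc1`: 20.1%
compound 3 `Cc1ccc(SCc2ccc(/C=C/C(=O)Nc3ccccc3N)cc2)cc1`: 22.2%

Compound 3 stands within the scatter of both other compounds, as a number 5.7 percentage points higher from compound 1 to compound 3 (within the scatter) and a number 2.1 percentage points higher from compound 2 to compound 3 (within the scatter) show. The next compound is compound 4 `Nc1ccccc1NC(=O)/C=C/c1ccc(CSCCc2ccccc2)cc1`, and the change is phenethyl in place of 4-methylphenyl on a sulfur. Two measured steps also exchange the group on that sulfur, and both are small: a number 3.6 percentage points higher from compound 1 to compound 2 (within the scatter) and a number 2.1 percentage points higher from compound 2 to compound 3 (within the scatter). For the measured compounds named here, no measured compound carries phenethyl there, so these steps are only indirect guides. In this assay, no step beyond the scatter is expected, and the estimated step is a number 1.2 percentage points lower from compound 3 to compound 4 (within the scatter). Compound 4 is expected at 21%, with an estimated range of 9% to 36%.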

Compound 4, percent growth inhibition at one concentration: 15.8%
Compound 4: middle estimate off by 5.2 percentage points, on the high side, and the stated range covers the measured number.
By their numbers in this assay, from the lowest: compounds 4, 1, 2 and 3 (each within the scatter of the next).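

Phenethyl is the first group on the sulfur that reaches its aromatic ring through a chain, and in this assay this change still gives no step beyond the scatter: a number 6.4 percentage points lower from compound 3 to compound 4 (within the scatter), a number 4.3 percentage points lower from compound 2 to compound 4 (within the scatter) and a number 0.7 percentage points lower from compound 1 to compound 4 (within the scatter). At this position, the read-out therefore does not separate phenethyl from the three aromatic groups directly on the sulfur. No evidence bearing on this result is available. Going by these compounds, it remains open whether an amine or a carboxylic acid on that sulfur, or a longer chain, would give a step beyond the scatter.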